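The source may hold more compounds than are shown below. What is called first, only, known or untested is meant among the compounds shown, and "the series" means these compounds.

In a functional assay on HepG2 cells (Homo sapiens) for cytotoxicity, read by MTT assay, with a stated time of 48 h (a higher number here means a weaker inhibitor, a lower number a stronger inhibitor), compound 1 `COc1ccc(C(=O)/C=C/c2ccc(OCc3cn(Cc4ccccc4)nn3)cc2)cc1` gives 9000 nM. Compound 2 `COc1ccc(C(=O)/C=C/c2ccc(OCc3cn(Cc4ccccc4Br)nn3)cc2)cc1` gives 20000 nM, and compound 3 `COc1ccc(C(=O)/C=C/c2ccc(OCc3cn(Cc4cccc(Br)c4)nn3)cc2)cc1` gives 60000 nM, the highest of the three numbers; its nearest neighbour is compound 2, with a 3.0-fold higher number from compound 2 to compound 3 (0.48 log units; beyond the scatter) beyond the scatter, and the step of a 6.7-fold higher number from compound 1 to compound 3 (0.82 log units; beyond the scatter) is larger still. Compound 4 `COc1ccc(C(=O)/C=C/c2ccc(OCc3cn(Cc4cccc(F)c4)nn3)cc2)cc1` differs from compound 3 by fluoro in place of bromo on an aromatic carbon. Within the data shown here, no measured step exchanges one halogen for another; the steps that come closest are a 6.7-fold higher number from compound 1 to compound 3 (0.82 log units; beyond the scatter) and a 2.2-fold higher number from compound 1 to compound 2 (0.35 log units; beyond the scatter), in which bromo enters for hydrogen and the number rises. Fluoro in place of bromo is therefore expected to sit between compound 1 and compound 3, most likely with a modest fall. Compound 4 is expected to show a 2.4-fold lower number from compound 3 to compound 4 (0.38 log units; beyond the scatter), an estimate of 25000 nM within a range from 10000 nM to 70000 nM.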

Compound 4, half-maximal inhibitory concentration: 85000 nM
The estimate for compound 4 lay 3.4-fold (0.53 log units) below the measured number; measured number outside the range, above it.
By their numbers in this assay, from the lowest: compound 1; then compound 2; then compounds 3 and 4 (each within the scatter of the next).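

Fluoro and bromo at this position on the benzyl ring cannot be told apart in this assay (a 1.4-fold higher number from compound 3 to compound 4 (0.15 log units; within the scatter)), so the high number of compound 3 is not confined to bromo. The 3-fluorobenzyl compound still stands clearly apart from the hydrogen parent (a 9.4-fold higher number from compound 1 to compound 4 (0.98 log units; beyond the scatter)) and from the 2-bromophenyl compound (a 4.3-fold higher number from compound 2 to compound 4 (0.63 log units; beyond the scatter)). No supporting evidence bears on why these numbers rise. On these data alone, whether an amine or a carboxylic acid at this place would give a number like those of the two halogens stays open, as does the effect of fluoro on the position that bromo holds in compound 2.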